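A few compounds are considered here, and "the series" means these few. Any claim that something is new, unique, unknown or untested is made for them only; others in the source may bear on it.

Of the compounds shown here, three built on a shared core have been tested in a functional assay on PC-3 cells (Homo sapiens) for inhibition, read by MTT assay, with a stated time of 48 h; a lower number here means a stronger inhibitor, a higher number a weaker inhibitor. Compound 1 `COc1ccc(CN(c2cc(OC)c(OC)c(OC)c2)S(=O)(=O)c2ccccc2)cc1` gives only > 50000 nM, which is a limit of the assay rather than a number (the limit of > 50000 nM in this assay, at which 1 of the 3 values shown sits). Among the compounds with values here, compound 2 `COc1ccc(CN(c2cc(OC)c(OC)c(OC)c2)S(=O)(=O)c2ccc(OC)c(OC)c2)cc1` gives 20100 nM in this assay, and the one measured step, an at least 2.4-fold lower number from compound 1 to compound 2 (0.39 log units; beyond the scatter), arises from 3,4-dimethoxyphenyl in place of phenyl on the sulfonyl sulfur. Compound 3 `COc1cc(N(Cc2ccc(Cl)cc2)S(=O)(=O)c2ccc(C)cc2)cc(OC)c1OC` gives 14600 nM in this assay; this is the lower of the two numbers shown, but its gap to compound 2 sits within the scatter, so the two cannot be ranked against each other.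

Compound 4 `COc1cc(N(Cc2ccccc2)S(=O)(=O)c2ccc(C)cc2)cc(OC)c1OC` differs from compound 3 by hydrogen in place of chloro on an aromatic carbon, which read one bond further out is 4-chlorobenzyl to benzyl. Within the data shown here, the single measured step concerns the group on the sulfonyl sulfur, not the benzyl ring, so nothing measured here bears directly on this change. The step is therefore expected to stay within the scatter, a 1.4-fold higher number from compound 3 to compound 4 (0.14 log units; within the scatter). Compound 4 is estimated at 20000 nM in this assay, between 8000 nM and 50000 nM.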

Compound 4, half-maximal inhibitory concentration: 7810 nM
Compound 4: middle estimate off by 2.6-fold (0.41 log units), on the high side, outside the stated range (below it).
By their numbers in this assay, from the lowest: compounds 4, 3 and 2 (each within the scatter of the next, the first and the last beyond it). At a limit, above all of these: compound 1.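

Within the data shown here, the first measured change on the benzyl ring, hydrogen in place of chloro on an aromatic carbon, gives in this assay a 1.9-fold lower number from compound 3 to compound 4 (0.27 log units; within the scatter). At this position, then, the chloro can be lost with no change that stands clear of the scatter, so compound 3 and compound 4 cannot be ranked, and the chloro is shown not to be required for a number of this size. Nothing measured here bears on why the step has this size.

As far as these compounds go, it remains open whether a fluoro, a nitrile or an amine on that same ring carbon would move the number beyond the scatter. From the compounds shown here alone, it is also open whether the step would read the same with the 3,4-dimethoxyphenyl of compound 2 on the sulfonyl sulfur.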